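Replacing methoxy with fluoro on compound 3

The source may report more compounds than this note shows. Statements on the series, on what has been measured and on what is new or still open speak of the compounds shown alone.

In a functional assay on MDA-MB-453 cells (Homo sapiens) for cytotoxicity, read by MTT assay, with a stated time of 48 h (a lower number here means a stronger inhibitor, a higher number a weaker inhibitor), compound 1 `COc1cc(C#N)ccc1OCc1nnc(-c2ccc(C)cc2)o1` gives 38400 nM. Compound 2 `N#Cc1ccc(OCc2nnc(-c3ccccc3)o2)cc1F` gives > 50000 nM, which is a limit of the assay and not a number. Compound 3 `COc1ccc(-c2nnc(COc3ccc(-c4nnco4)cc3)o2)cc1` gives 36200 nM. Within the data shown here, this lies within the usual scatter of compound 1, the only other compound here with an exact number, so the two cannot be ranked.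

Compound 4 `Fc1ccc(-c2nnc(COc3ccc(-c4nnco4)cc3)o2)cc1` has not yet been measured. It differs from compound 3 in one place: fluoro in place of methoxy on an aromatic carbon. This puts fluoro in place of methoxy on an aromatic carbon, para to a large group.

Among the measured compounds shown here, no measured pair shows this swap, so the expectation in this assay rests only on how close compound 1 at 38400 nM and compound 3 at 36200 nM lie. The expected change is slight and no larger than the usual scatter, a 1.1-fold higher number from compound 3 to compound 4 (0.04 log units; within the scatter). Compound 4 may also return only a limit, as compound 2 did. For compound 4 the estimated value is 40000 nM, with an expected range of 18000 nM to 60000 nM.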

Compound 4, half-maximal inhibitory concentration: 38200 nM
For compound 4 the middle estimate is 1.0-fold (0.02 log units) above the measured one, within the range that was stated.
By their numbers in this assay, from the lowest: compounds 3, 4 and 1 (each within the scatter of the next). At a limit, above all of these: compound 2.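

In this assay, the swap of methoxy for fluoro on an aromatic carbon, para to a large group, now has a first measured step: a 1.1-fold higher number from compound 3 to compound 4 (0.02 log units; within the scatter). The 4-methoxyphenyl and 4-fluorophenyl versions therefore cannot be told apart in this assay, so at this position, the methoxy group can be exchanged for fluoro with no readable change in the number. Compound 4 also gives an exact number, and compound 2 remains the only compound at a limit of the assay: the limit of > 50000 nM in this assay, at which 1 of the 4 values shown sits.

What the compounds shown leave open is whether any group at this position can shift the number beyond the scatter, such as an amine, a carboxylic acid or a longer alkyl chain. This single step also cannot show whether the same swap would behave alike on a different core.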